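This account rests on a few compounds, and the source may have more. Where it says the series, first, only, none or still open, it means among the compounds named here.

The shared core is seen in compound 1 `C=CCn1c(=O)/c(=C\c2cccc(Cl)c2)[nH]c(=O)/c1=C\c1ccccc1OC`, which carries a 3-chlorophenyl on one double-bonded chain carbon and a 2-methoxyphenyl on the other. In a functional assay on MOLT-4 cells (Homo sapiens) for cytotoxicity, read by CCK-8 assay, with a stated time of 72 h (a lower number here means a stronger inhibitor, a higher number a weaker inhibitor), compound 1 gives 4900 nM. Compound 2 `C=CCn1c(=O)/c(=C\c2ccc(Cl)c(Cl)c2)[nH]c(=O)/c1=C\c1ccccc1OC`, bearing a second chlorine on that ring, is reported in this assay as "not active" (no number reported). Going by the values given here, compound 3 `C=CCn1c(=O)/c(=C\c2ccccc2OC)[nH]c(=O)/c1=C\c1ccccc1OC`, with 2-methoxyphenyl on both double-bonded chain carbons, gives 13100 nM in this assay, the highest of the two numbers reported; the one measured step is a 2.7-fold higher number from compound 1 to compound 3 (0.43 log units; beyond the scatter). Compound 4 `C=CCn1c(=O)/c(=C\c2ccccc2C(F)(F)F)[nH]c(=O)/c1=C\c1ccccc1OC` differs from compound 3 by trifluoromethyl in place of methoxy on an aromatic carbon. Among the compounds with values here, no measured step exchanges a methoxy for a trifluoromethyl, nor touches this aryl group at all; the only step recorded concerns the other aryl group, and it was modest. The data therefore give no direction for this change, and the expected step is a 1.2-fold lower number from compound 3 to compound 4 (0.08 log units; within the scatter). Compound 4 is estimated at 11000 nM in this assay, with a range from 3000 nM to 40000 nM.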

Compound 4, half-maximal inhibitory concentration: 4400 nM
For compound 4 the middle estimate is 2.5-fold (0.40 log units) above the measured one; low and high end bracket the measured number.
By their numbers in this assay, from the lowest: compounds 4 and 1 (each within the scatter of the next); then compound 3.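

Going by these compounds alone, with the aryl group on the other double-bonded chain carbon held fixed, the group on this aromatic carbon matters in this assay: trifluoromethyl in place of methoxy gives a 3.0-fold lower number from compound 3 to compound 4 (0.47 log units; beyond the scatter) and is the first measured exchange at this position. The 2-(trifluoromethyl)phenyl and 3-chlorophenyl groups are not separated by this assay, since the exchange gives a 1.1-fold lower number from compound 1 to compound 4 (0.05 log units; within the scatter) and so shows that the number reached with a 3-chlorophenyl is also reached with this differently substituted ring. Nothing available explains the step from methoxy to trifluoromethyl.

The compounds shown leave open how a nitrile or a dimethylamino group would behave on this aromatic carbon. They also leave open whether the step holds when the 2-methoxyphenyl on the other double-bonded chain carbon is exchanged.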